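This account rests on a few compounds, and the source may have more. Where it says the series, first, only, none or still open, it means among the compounds named here.

Of the compounds shown here, two have so far been measured in a functional assay on L6 cells (Rattus norvegicus) for inhibition; on this read-out lower numbers stand for stronger inhibition and higher numbers for weaker inhibition. Compound 1 `Cc1ccc(CNC(=O)c2nn(-c3ccc(F)cc3)c(CC[C@@H](O)C[C@@H](O)CC(=O)O)c2C(C)C)cc1` gives 800 nM, while compound 2 `CC(C)c1c(C(=O)N(C)Cc2ccccc2)nn(-c2ccc(F)cc2)c1OC[C@@H](O)C[C@@H](O)CC(=O)O` gives 6720 nM. Compound 2 therefore has the higher of the two numbers, and the gap between them lies beyond the usual scatter. The next compound, compound 3 `Cc1ccccc1CNC(=O)c1nn(-c2ccc(F)cc2)c(OC[C@@H](O)C[C@@H](O)CC(=O)O)c1C(C)C`, contains the same atoms as compound 2, joined differently: (2-methylbenzyl)amino in place of benzyl(methyl)amino on a carbonyl carbon. In words, (2-methylbenzyl)amino stands in place of benzyl(methyl)amino on a carbonyl carbon. For the measured compounds named here, the two measured compounds differ in more than one place, so no measured pair isolates this change. Going by the values given here, the only guide is compound 1, which also has the amide hydrogen and a methylbenzyl group and gives 800 nM, although it differs from compound 3 elsewhere as well. On that limited evidence, a moderate shift towards stronger inhibition in this assay is expected, with considerable uncertainty: the expected change is a 3.4-fold lower number from compound 2 to compound 3 (0.53 log units; beyond the scatter). Compound 3 is estimated at 2000 nM, with an expected range from 400 nM to 9000 nM.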

Compound 3, half-maximal inhibitory concentration: 2850 nM
Compound 3: middle estimate off by 1.4-fold (0.15 log units), on the low side, and the stated range covers the measured number.
By their numbers in this assay, from the lowest: compound 1; then compound 3; then compound 2.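

In this assay, for the compounds shown here, the exchange of benzyl(methyl)amino for (2-methylbenzyl)amino on the carbonyl carbon gives a 2.4-fold lower number from compound 2 to compound 3 (0.37 log units; beyond the scatter), the first measured change at this place with the rest of the molecule held constant. The step is modest but beyond the scatter, so this place responds to a rearrangement that leaves the heavy-atom count and the aromatic ring count unchanged and adds only the amide hydrogen as a hydrogen-bond donor. Nothing available explains this shift in inhibition.

The change moves a methyl group from the amide nitrogen to the aromatic ring and so alters two features in one step, leaving the contribution of the amide hydrogen unresolved from that of the ring methyl. Plain benzylamino, which has the amide hydrogen and no methyl group at all, would separate the two, while 2-chlorobenzylamino or 2-methoxybenzylamino would show whether the number depends on the methyl group itself or tolerates other groups in its place.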